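The source may hold more compounds than are shown below. What is called first, only, known or untested is meant among the compounds shown, and "the series" means these compounds.

Of the compounds shown here, three with a shared core have been measured in a functional assay on MCF7 cells (Homo sapiens) for antiproliferative activity, read by MTT assay, with a stated time of 72 h; a lower number here means a stronger inhibitor, a higher number a weaker inhibitor. Compound 1 `CCN1CCN(c2cc(C)c3cc(NC(=O)c4ccccc4F)ccc3n2)CC1` gives 32600 nM, the highest number of the three. For the measured compounds named here, its closest neighbour is compound 3 `CCN1CCN(c2cc(C)c3cc(NC(=O)c4ccccc4C)ccc3n2)CC1`, which gives 10900 nM; the only single-site step measured is a 3.0-fold lower number from compound 1 to compound 3 (0.48 log units; beyond the scatter). Further away lies compound 2 `CCN(CC)CCNc1cc(C)c2cc(NC(=O)c3ccc(Cl)c(Cl)c3)ccc2n1`, which gives 1420 nM and differs from compound 1 in more than one place, so no single step can be read from that pair.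

Compound 4 `CCN1CCN(c2cc(C)c3cc(NC(=O)c4ccc5ccccc5n4)ccc3n2)CC1` has not yet been measured. It differs from compound 1 in one place: quinolin-2-yl in place of 2-fluorophenyl on a carbonyl carbon. Going by the values given here, no measured step changes this part of the molecule in the same way; the step from compound 1 to compound 3 alters the same ring but only swaps one small group for another, and it was modest. On that thin basis a modest improvement is expected, with wide uncertainty. For compound 4 the estimate is 9000 nM, ranging from 2500 nM to 32000 nM, which would correspond to an expected 3.6-fold lower number from compound 1 to compound 4 (0.56 log units; beyond the scatter).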

Compound 4, half-maximal inhibitory concentration: 7060 nM
Compound 4: the middle estimate sits 1.3-fold (0.11 log units) above what was measured; low and high end bracket the measured number.
By their numbers in this assay, from the lowest: compound 2; then compounds 4 and 3 (each within the scatter of the next); then compound 1.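

On the carbonyl carbon, the swap of 2-fluorophenyl for the larger quinolin-2-yl, which adds a second ring and a ring nitrogen, still gives a 4.6-fold lower number from compound 1 to compound 4 (0.66 log units; beyond the scatter) in this assay, so this position accepts more than a small change on the ring. Against 2-methylphenyl, quinolin-2-yl gives a 1.5-fold lower number from compound 3 to compound 4 (0.19 log units; within the scatter) and the two groups cannot be told apart, so the second ring brings no measurable gain over that simpler ring. Nothing measured here explains why the numbers fall this way.

Going by these compounds, it remains open whether an unsubstituted phenyl, or a ring carrying an amine or a carboxylic acid, would change the number at this carbonyl carbon. For the compounds shown here, the separate contributions of the two chlorines and the diethylamino chain of compound 2 cannot be read, since no single-place step links compound 2 to the others.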